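Substituted aryl on the ring nitrogen of compound 3

The source may hold more compounds than are shown below. What is called first, only, known or untested is meant among the compounds shown, and "the series" means these compounds.

The measured compounds are few:
compound 1, `CNC(=O)c1cc(Oc2ccc(NC(=O)c3cc4cccnc4n(-c4ccccc4)c3=O)cc2)ccn1`, which in a functional assay on A549 cells (Homo sapiens) for antiproliferative activity, read by MTT assay, with a stated time of 72 h (on this read-out lower numbers stand for stronger inhibition and higher numbers for weaker inhibition), gives 200 nM;
compound 2, `CNC(=O)c1cc(Oc2ccc(NC(=O)c3cc4cccnc4n(-c4ccc(OC)cc4)c3=O)cc2)ccn1`, which in this assay gives 3110 nM;
compound 3, `CCNC(=O)c1cc(Oc2ccc(NC(=O)c3cc4cccnc4n(-c4ccccc4)c3=O)cc2)ccn1`, which in this assay gives 160 nM.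

Compound 3 carries the smallest of the three numbers, but its gap to compound 1, a 1.3-fold lower number from compound 1 to compound 3 (0.10 log units; within the scatter), is within the scatter, so the two cannot be told apart; compound 2 stands well above both. Compound 4, `CCNC(=O)c1cc(Oc2ccc(NC(=O)c3cc4cccnc4n(-c4ccc(C(F)(F)F)cc4Cl)c3=O)cc2)ccn1`, differs from compound 3 by 2-chloro-4-(trifluoromethyl)phenyl in place of phenyl on an aromatic nitrogen. Of the measured steps, only one touches that aryl: placing a methoxy on it gave a 16-fold higher number from compound 1 to compound 2 (1.19 log units; beyond the scatter), a large rise. Among the measured compounds shown here, the step of a 1.3-fold lower number from compound 1 to compound 3 (0.10 log units; within the scatter) concerns the other end of the molecule and shows only that compound 3 tracks compound 1. Since compound 2 shows that substitution on this aryl raised the number, because of a 16-fold higher number from compound 1 to compound 2 (1.19 log units; beyond the scatter) compound 4 is expected to show a rise of about a 6.3-fold higher number from compound 3 to compound 4 (0.80 log units; beyond the scatter) in this assay. Compound 4 is therefore estimated at 1000 nM, within a range of 300 nM to 4000 nM.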

Compound 4, half-maximal inhibitory concentration: 3290 nM
For compound 4 the middle estimate is 3.3-fold (0.52 log units) below the measured one; low and high end bracket the measured number.
By their numbers in this assay, from the lowest: compounds 3 and 1 (each within the scatter of the next); then compounds 2 and 4 (each within the scatter of the next).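

In this assay the step of a 21-fold higher number from compound 3 to compound 4 (1.31 log units; beyond the scatter) is a second large rise on the aryl at the ring nitrogen, alongside the earlier 16-fold higher number from compound 1 to compound 2 (1.19 log units; beyond the scatter) seen with methoxy. The rise on this aryl is thus not confined to methoxy or to the compound with the shorter amide chain: both substituted aryls shown carry higher numbers than their phenyl partners, and no compound shown goes against this. Nothing shown gives a reason for the rise.

Chloro and trifluoromethyl enter together in compound 4, so the share of each in the step stays open. Also open, from the compounds shown here alone, is what an aryl carrying an amine or a carboxylic acid, or an ethyl chain in place of the aryl, would give at this position.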